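Aryloxymethyl thiosemicarbazone series: cytotoxicity notes

The source may hold more compounds than are shown below. What is called first, only, known or untested is meant among the compounds shown, and "the series" means these compounds.

Measured so far:
- compound 1, `CCc1ccc(OC/C(=N\NC(N)=S)c2ccc(Br)cc2)cc1`: < 25500 nM
- compound 2, `NC(=S)N/N=C(\COc1cccc(Cl)c1Cl)c1ccc(Br)cc1`: 23100 nM

Both compounds carry the same core and differ only in the substitution of the aryloxy ring. In an ADME assay on L929 cells (Mus musculus) for cytotoxicity, read by resazurin assay, with a stated time of 96 h (on this read-out lower numbers stand for higher toxicity in this test and higher numbers for lower toxicity in this test), compound 1 gives < 25500 nM, which is a limit of this assay and not a measured number. In this assay compound 2 gives 23100 nM. Going by the values given here, compound 1 therefore stands at the limit of < 25500 nM in this assay, at which 1 of the 2 values shown sits, and no numerical step between the two compounds can be drawn from these values; the two values show only that compound 2 sits close to where the limit of compound 1 lies.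

The next compound, compound 3, `NC(=S)N/N=C(\COc1ccc(I)cc1)c1ccc(Br)cc1`, is obtained from compound 1 by the change (iodo in place of ethyl on an aromatic carbon). Among the compounds with values here, no measured step covers such a change, so no direction is fixed by the data. The expectation for this assay is a step of no size beyond the usual scatter, as a step that the limit leaves unreadable from compound 1 to compound 3. On that basis compound 3 is estimated at 20000 nM in this assay, with a range from 8000 nM to 45000 nM.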

Compound 3, half-maximal cytotoxic concentration: < 20400 nM
Compound 3: a limit, no number; the forecaster's own chance of this, stated with the estimate: 35%; the middle value does not contradict the limit.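

In this assay compound 3 gives < 20400 nM, which is a limit of the assay and not a number. Going by these compounds alone, compound 1 also stands at a limit, so no step between compound 1 and compound 3 can be read. The compounds shown leave open whether iodo in place of ethyl on an aromatic carbon shifts the half-maximal cytotoxic concentration at all.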